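The source may report more compounds than this note shows. Statements on the series, on what has been measured and on what is new or still open speak of the compounds shown alone.

Compound 1 `Fc1ccc(Cc2ccc3c(NCCCNCc4ccco4)ccnc3c2)c(Cl)c1` and compound 2 `Cc1cc(C)cc(Cc2ccc3c(NCCCNCc4ccco4)ccnc3c2)c1` share one core and differ only in the aryl group on the benzylic carbon. In a physicochemical assay for acid dissociation, compound 1 gives 9.47, and compound 2 gives 9.47; that step no change at the digits printed from compound 1 to compound 2 (within the scatter) places compound 1 level with compound 2. Compound 3 `COc1cccc(CNCCCNc2ccnc3cc(Cc4ccc(F)cc4Cl)ccc23)c1O` changes a different part of the molecule: 2-hydroxy-3-methoxyphenyl in place of furan-2-yl on a saturated chain carbon bound to an amine nitrogen. Among the measured compounds shown here, no measured step touches this position, so the one step seen, at a remote place and without change, offers only weak guidance. A small step of a number 0.13 log units higher from compound 1 to compound 3 (within the scatter) is therefore expected. Compound 3 is estimated at 9.6, within 9.1 to 10.1.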

Compound 3, acid dissociation constant: 9.47
For compound 3 the middle estimate is 0.13 log units above the measured one; low and high end bracket the measured number.
By their numbers in this assay, from the lowest: compounds 1, 2 and 3 (each within the scatter of the next).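

In this assay, among the compounds shown here, 2-hydroxy-3-methoxyphenyl in place of furan-2-yl on a saturated chain carbon bound to an amine nitrogen gives no change at the digits printed from compound 1 to compound 3 (within the scatter), the first reading at this place. This exchange of a five-membered aromatic ring for a larger six-membered one, with a hydrogen-bond donor entering, thus leaves the read-out level, as the aryl exchange at the other place did. Nothing shown accounts for this reading.

For the compounds shown here, only this one exchange is seen here. As far as these compounds go, whether a carboxylic acid or a second amine in place of furan-2-yl, or a longer chain at this place, would also leave the read-out level remains open.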